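A Carbamate in Place of a Benzylamine on the Shared Core

The compounds below may be only part of what the source reports. "The series", "measured", "known", "first", "only" and "open" are said of these compounds alone.

Compound 3 `CCCCC1(CCCC)CS(=O)(=O)c2ccc(NCc3ccccc3)cc2[C@@H](c2ccccc2)[C@H]1O` carries a benzylamino group on the aromatic ring of the shared core. Among the compounds with values here, in an assay on cells for inhibition of ileal sodium/bile acid cotransporter (Homo sapiens) (on this read-out higher numbers stand for weaker inhibition and lower numbers for stronger inhibition), compound 3 gives 1900 nM, the highest of the three numbers measured so far. Compound 2 `CCCCC1(CCCC)CS(=O)(=O)c2ccc([N+](C)(C)C)cc2[C@@H](c2ccccc2)[C@H]1O` gives 210 nM, and compound 1 `CCCCCC(=O)Nc1ccc2c(c1)[C@@H](c1ccccc1)[C@@H](O)[C@](CC)(CCCC)CS2(=O)=O`, whose ring nitrogen bears a carbonyl group rather than a benzyl, gives 300 nM. Within the data shown here, the only step with a single change is a 9.0-fold higher number from compound 2 to compound 3 (0.96 log units; beyond the scatter); it concerns the group on the aromatic carbon and does not touch the nitrogen of compound 3 itself.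

Compound 4 `CCCCC1(CCCC)CS(=O)(=O)c2ccc(NC(=O)OCc3ccccc3)cc2[C@@H](c2ccccc2)[C@H]1O` differs from compound 3 by benzyloxycarbonyl in place of benzyl on a nitrogen on an aromatic ring. Among the measured compounds shown here, no measured step covers this change. Compound 1 and compound 3 differ in more than one place, yet their two values show that a carbonyl on the ring nitrogen goes with a clearly lower number than the benzylamine of compound 3. Compound 4 is therefore expected to move toward stronger inhibition by about a 2.7-fold lower number from compound 3 to compound 4 (0.43 log units; beyond the scatter). That comparison is not a clean single-change one, and the uncertainty is wide. The estimate for compound 4 in this assay is 700 nM, within 200 nM to 2500 nM.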

Compound 4, half-maximal inhibitory concentration: 600 nM
Compound 4: the middle estimate sits 1.2-fold (0.07 log units) above what was measured; the range from low to high includes it.
By their numbers in this assay, from the lowest: compounds 2, 1 and 4 (each within the scatter of the next, the first and the last beyond it); then compound 3.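

Within this assay, the change from benzyl to benzyloxycarbonyl on this nitrogen gives a 3.2-fold lower number from compound 3 to compound 4 (0.50 log units; beyond the scatter) and is the first single-change reading at this nitrogen. Both groups carry a six-membered aromatic ring of carbon only, so that ring alone does not fix the number; what differs is the stretch linking it to the nitrogen, which now holds a carbonyl and an oxygen. The gain does not close the whole gap to the ringless group on the same aromatic carbon, since the series shows a 2.9-fold higher number from compound 2 to compound 4 (0.46 log units; beyond the scatter) and nothing measured here says why either step has the size it has.

The compounds shown leave open whether the carbonyl, the added oxygen or the ring of benzyloxycarbonyl matters most, and an acetyl or a methoxycarbonyl group on this nitrogen would begin to separate these parts. A free amine on the same aromatic carbon would also give a plain reference point for the benzyl and benzyloxycarbonyl groups alike, which the present set lacks.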